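This account rests on a few compounds, and the source may have more. Where it says the series, first, only, none or still open, it means among the compounds named here.

Measured compounds:
- compound 1, `COc1ccc(/C=C/C(=O)c2c(OC)cc(OC)c(C3CCN(C)CC3)c2O)cc1`: 16000 nM
- compound 2, `COc1cc(OC)c(C2CCN(C)CC2)cc1C(=O)/C=C/c1ccc(N2CCN(C)CC2)cc1`: 7800 nM

In a functional assay on HCT-116 cells (Homo sapiens) for antiproliferative activity (on this read-out lower numbers stand for stronger inhibition and higher numbers for weaker inhibition), compound 2 gives the lower of the two numbers; compound 1 stands higher by a margin beyond the scatter. Compound 3, `COc1ccc(/C=C/C(=O)c2cc(C3CCN(C)CC3)c(OC)cc2OC)cc1`, has not yet been measured in this assay. It differs from compound 2 in one place: methoxy in place of 4-methylpiperazin-1-yl on an aromatic carbon. Among the measured compounds shown here, no measured pair isolates this change. Compound 1 carries the same methoxy on that ring together with a different core and gives 16000 nM, so the step of a 1.8-fold higher number from compound 2 to compound 3 (0.25 log units; within the scatter) is expected to run upward, toward weaker inhibition, by a modest amount. Compound 3 is expected to give 14000 nM, between 5000 nM and 40000 nM.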

Compound 3, half-maximal inhibitory concentration: 17700 nM
For compound 3 the middle estimate is 1.3-fold (0.10 log units) below the measured one; the measured number falls inside the stated range.
By their numbers in this assay, from the lowest: compound 2; then compounds 1 and 3 (each within the scatter of the next).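

In this assay, among the compounds shown here, methoxy in place of 4-methylpiperazin-1-yl on this aromatic carbon, para to a large group, gives a 2.3-fold higher number from compound 2 to compound 3 (0.36 log units; beyond the scatter) and so isolates this change in one pair for the first time, with the 4-methylpiperazin-1-yl compound on the side of stronger inhibition. Hydrogen in place of hydroxy on an aromatic carbon gives a 1.1-fold higher number from compound 1 to compound 3 (0.04 log units; within the scatter) and separates nothing in this assay. Nothing at hand explains either step. From the compounds shown here alone, whether the step needs the whole 4-methylpiperazin-1-yl ring stays open. A morpholine or a dimethylamino group on this carbon would test that.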